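The source may report more compounds than this note shows. Statements on the series, on what has been measured and on what is new or still open speak of the compounds shown alone.

Among the measured compounds shown here, in an ADME assay on microsomes from liver (Rattus norvegicus, strain Wistar) for metabolic stability, tested at 2.5 uM (a higher number here means faster removal of the compound, a lower number slower removal), compound 1 `Brc1cccc2c1nnn2Cc1ccccc1` gives 2 mL/min/g and stands highest of the two numbers known so far, though its nearest neighbour sits within the scatter of it. That neighbour is compound 2 `Fc1ccccc1Cn1nnc2c(Br)cccc21`, which in this assay gives 1.8 mL/min/g; the step of a 1.1-fold lower number from compound 1 to compound 2 (0.05 log units; within the scatter) came from fluoro in place of hydrogen on an aromatic carbon, and it did not rise above the scatter.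

Compound 3 `Fc1ccc(Cn2nnc3c(Br)cccc32)cc1` is built from compound 1 by a change of the same kind, placed differently on the ring:

fluoro in place of hydrogen on an aromatic carbon

For the measured compounds named here, the only measured step that bears on this move is the one from compound 1 to compound 2, and it was within the scatter. A step of similar size in this assay is therefore expected, with no shift beyond the scatter in either direction, which means no change at the digits printed from compound 1 to compound 3 (within the scatter). For compound 3 the estimated clearance is 2 mL/min/g, with a range from 1 mL/min/g to 4 mL/min/g.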

Compound 3, intrinsic clearance in a liver preparation (reported as CLH), per the amount of preparation that the assay uses: 1 mL/min/g
The estimate for compound 3 lay 2.0-fold (0.30 log units) above the measured number; measured number inside the range.
By their numbers in this assay, from the lowest: compounds 3, 2 and 1 (each within the scatter of the next).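

In this assay, fluoro in place of hydrogen on an aromatic carbon, para to a large group, gives a 2.0-fold lower number from compound 1 to compound 3 (0.30 log units; within the scatter) and so stays within the scatter. The earlier step, a 1.1-fold lower number from compound 1 to compound 2 (0.05 log units; within the scatter), was also within the scatter, so for the two fluoro placements shown, this swap makes no clear difference to how fast the compound is removed. Nothing measured here speaks to what lies behind these small steps.

Still open, going by these compounds, is whether a different group at the same place on the ring, such as an amine, a methoxy group or a carboxylic acid, would carry the number beyond the scatter. The compounds shown also leave open what happens when the bromine on the shared core gives way to another group, such as a nitrile.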